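The source may report more compounds than this note shows. Statements on the series, on what has been measured and on what is new or still open speak of the compounds shown alone.

Working notes on the series. Compound 1 `CNC(=O)c1cccc(S(=O)(=O)Oc2ccc(-c3cncn3C3CCN(C(=O)c4ccc(S(C)(=O)=O)cc4)CC3)cc2)c1` gives 202 nM in an assay on HEK293 cells for antagonist activity at P2X purinoceptor 7 (Homo sapiens), read by fluorescence, with a stated time of 2 h; a lower number here means a stronger inhibitor, a higher number a weaker inhibitor. Compound 2 `CNC(=O)c1cccc(S(=O)(=O)Oc2ccc(-c3cncn3C3CCN(C(=O)c4ccc([N+](=O)[O-])cc4)CC3)cc2)c1` gives 62 nM in this assay. The two differ by nitro in place of methylsulfonyl on an aromatic carbon, and the step is a 3.3-fold lower number from compound 1 to compound 2 (0.51 log units; beyond the scatter). Compound 3 `CS(=O)(=O)c1ccc(C(=O)N2CCC(n3cncc3-c3ccc(OS(=O)(=O)c4cccc(C(=O)NC5CC5)c4)cc3)CC2)cc1` gives 400 nM in this assay; its core differs from the core of compound 1 by cyclopropyl in place of methyl on an amide-type nitrogen, with a step of a 2.0-fold higher number from compound 1 to compound 3 (0.30 log units; within the scatter). Compound 4 `O=C(NC1CC1)c1cccc(S(=O)(=O)Oc2ccc(-c3cncn3C3CCN(C(=O)c4ccc([N+](=O)[O-])cc4)CC3)cc2)c1` has not yet been measured in this assay. Its difference from compound 3 is nitro in place of methylsulfonyl on an aromatic carbon; the place of this change reads word for word as the place of the change from compound 1 to compound 2, so it is the same change, carried out on the core of compound 3 instead. The change occurs twice among the compounds shown, once measured and once not. Within the data shown here, the step from compound 3 to compound 4 is expected to be a 3.3-fold lower number from compound 3 to compound 4 (0.52 log units; beyond the scatter), resting on a 3.3-fold lower number from compound 1 to compound 2 (0.51 log units; beyond the scatter), the one measured instance of this change. On that basis compound 4 is estimated at 120 nM, with a likely range from 55 nM to 260 nM.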

Compound 4, half-maximal inhibitory concentration: 152 nM
Beside the measured number, compound 4's estimate is 1.3-fold (0.10 log units) below it, within the range that was stated.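

In this assay, nitro in place of methylsulfonyl on an aromatic carbon gives a 2.6-fold lower number from compound 3 to compound 4 (0.42 log units; beyond the scatter), and the size of this step holds from one core to the other: the same change on two cores in this assay, a 3.3-fold lower number (0.51 log units; beyond the scatter) from compound 1 to compound 2 and a 2.6-fold lower number (0.42 log units; beyond the scatter) from compound 3 to compound 4, 1.2-fold (0.09 log units) apart, within the scatter of two such steps. Cyclopropyl in place of methyl on the amide-type nitrogen gives a 2.5-fold higher number from compound 2 to compound 4 (0.39 log units; beyond the scatter), and this step also holds across the two cores: the same change on two cores in this assay, a 2.0-fold higher number (0.30 log units; within the scatter) from compound 1 to compound 3 and a 2.5-fold higher number (0.39 log units; beyond the scatter) from compound 2 to compound 4, 1.2-fold (0.09 log units) apart, within the scatter of two such steps. Within these four compounds the two changes therefore behave independently of each other, but each rests on a single pair of cores, which does not show that either step would hold on a core changed elsewhere, nor why the steps have the size they do.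

The compounds shown leave open whether a nitrile, a carboxylic acid or an amine in place of methylsulfonyl would follow nitro in this assay. They also leave open how a longer chain on the amide-type nitrogen would compare with methyl and cyclopropyl.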